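A few compounds are considered here, and "the series" means these few. Any claim that something is new, unique, unknown or untested is made for them only; others in the source may bear on it.

Compound 1 `O=S(=O)(c1ccccc1)c1ccc(O)nn1`: 14%
Compound 2 `O=S(=O)(c1ccc(O)nn1)c1ccccc1F`: 34%

Compound 2 stands highest of the two numbers in a functional assay on the whole organism for inhibition, with Rattus norvegicus as the target, with a stated time of 60 min, at pH 4.5, at a dose of 10 mg/kg by the oral route; a lower number here means a weaker effect, a higher number a stronger effect of the compound at the dose given; its nearest neighbour is compound 1, whose value of 14% lies well below it. Compound 3, `O=S(=O)(c1ccc(O)nn1)c1ccc(Br)cc1F`, differs from compound 2 by bromo in place of hydrogen on an aromatic carbon. For the measured compounds named here, the only measured step that bears on this is a number 20 percentage points higher from compound 1 to compound 2 (beyond the scatter), a halogen entering on an aromatic carbon of compound 1. A second halogen entering the same way is therefore expected to bring a modest rise, a number 11 percentage points higher from compound 2 to compound 3 (beyond the scatter), though one precedent carries little weight. Compound 3 is estimated at 45%, within 25% to 65%.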

Compound 3, a percentage reported as inhibition, in the whole organism at one dose (the size of the read-out at that dose, not a potency): 67%
Compound 3: middle estimate off by 22 percentage points, on the low side, outside the stated range (above it).
By their numbers in this assay, from the lowest: compound 1; then compound 2; then compound 3.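

In this assay, bromo on the aromatic carbon para to a large group and meta to a fluoro group brings a number 33 percentage points higher from compound 2 to compound 3 (beyond the scatter), so this position takes a halogen with a large gain. The fluoro group stays in place, and this gain comes on top of a number 20 percentage points higher from compound 1 to compound 2 (beyond the scatter): a second halogen on the ring adds further rather than levelling off. Nothing at hand explains the size of this gain.

From the compounds shown here alone, whether bromo on the core of compound 1 would give a similar gain without the fluoro group stays open. So does whether the gain is specific to a halogen, since a methoxy group or an amine at this position could answer that.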